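The compounds below may be only part of what the source reports. "The series", "measured", "known", "first", "only" and "open" are said of these compounds alone.

Three compounds of this series carry numbers in a functional assay on the whole organism (strain AKR) for inhibition, with Mus musculus as the target, read by paw edema, with a stated time of 3.5 h, at a dose of 0.01 mmol/kg by the intraperitoneal route; a higher number here means more inhibition at the dose given (going by the name of the read-out), a lower number less inhibition. Compound 1 `O=C1N/C(=N\c2nccs2)S/C1=C\c1cccc(O)c1` gives 33.7%, compound 2 `COc1cc(/C=C2\S/C(=N\c3nccs3)NC2=O)cc(OC)c1O` gives 39%, and compound 3 `O=C1N/C(=N\c2nccs2)S/C1=C\c1cccc(F)c1` gives 56.6%, the highest of the three, with compound 2 nearest and compound 1 furthest, both beyond the scatter. For the measured compounds named here, the one single-point step among them, a number 22.9 percentage points higher from compound 1 to compound 3 (beyond the scatter), is fluoro in place of hydroxy on an aromatic carbon.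

Compound 4 `O=C1N/C(=N\c2nccs2)S/C1=C\c1cccc(Br)c1` is the next member: bromo in place of fluoro on an aromatic carbon, on an aromatic carbon of a six-membered aromatic ring of carbon only, meta to a large group. Going by the values given here, no measured step exchanges one halogen for another, so the step from compound 1 to compound 3 bears only loosely on this change, showing only that the number is higher with fluoro than with hydroxy. With nothing closer to lean on, the expected step of a number 1.6 percentage points lower from compound 3 to compound 4 (within the scatter) is none beyond the scatter. Compound 4 is therefore estimated at 55% in this assay, with a range from 40% to 70%.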

Compound 4, a percentage reported as inhibition, in the whole organism at one dose (the size of the read-out at that dose, not a potency): 42.7%
Beside the measured number, compound 4's estimate is 12.3 percentage points above it, within the range that was stated.
By their numbers in this assay, from the lowest: compounds 1, 2 and 4 (each within the scatter of the next); then compound 3.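

Halogen identity matters at this place, on an aromatic carbon meta to a large group: in this assay, bromo in place of fluoro gives a number 13.9 percentage points lower from compound 3 to compound 4 (beyond the scatter), so the higher number seen with fluoro does not extend to every halogen. Bromo in place of hydroxy gives a number 9 percentage points higher from compound 1 to compound 4 (within the scatter), which leaves these two groups unseparated in this read-out and leaves fluoro alone above both. Nothing measured here accounts for the difference between fluoro and bromo.

Open, from the compounds shown here alone, is what chloro, methoxy or an amine would give at this same place, and so whether fluoro stands alone or belongs to a wider set of groups. Each number also comes from a single dose, so the order of these compounds at other doses remains open.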